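A few compounds are considered here, and "the series" means these few. Any claim that something is new, unique, unknown or untested is made for them only; others in the source may bear on it.

In an ADME assay on WI-38 cells (Homo sapiens) for inhibition, read by MTT assay, with a stated time of 72 h (on this read-out lower numbers stand for stronger inhibition and higher numbers for weaker inhibition), compound 1 `NC1(CCn2cc(F)c(=O)[nH]c2=O)OC(=O)C(OCc2ccccc2)=C1OCc1ccccc1` gives 36200 nM, which is the higher of the two numbers recorded among the measured compounds. Compound 2 `O=C1O/C(=C\Cn2ccc(NC(=O)c3ccccc3)nc2=O)C(OCc2ccccc2)=C1OCc1ccccc1` gives 8490 nM in this assay, and the gap between compound 1 and compound 2 lies beyond the usual scatter. Compound 3 `Nc1ncn(C[C@H](O)[C@H]2OC(=O)C(OCc3ccccc3)=C2OCc2ccccc2)c(=O)n1` returns a limit of this assay rather than a number, > 100000 nM; this corresponds to the limit of > 100000 nM in this assay, at which 1 of the 3 values shown sits. Compound 4 `Nc1ccn(CCC2(N)OC(=O)C(OCc3ccccc3)=C2OCc2ccccc2)c(=O)n1` has not yet been measured in this assay. It differs from compound 1 in a single place: a group of 8 heavy atoms (4 carbon, 3 nitrogen, 1 oxygen; one six-membered aromatic ring with 2 hetero atoms) in place of a group of 9 heavy atoms (4 carbon, 2 nitrogen, 2 oxygen, 1 fluorine; one six-membered aromatic ring with 2 hetero atoms), on a saturated chain carbon, two bonds along the chain from a saturated ring carbon. Among the compounds with values here, no pair of measured compounds differs in only this one place, so the size of this step is not known from the data. Compound 4 is expected to sit at a somewhat higher number than compound 1, with the step of a 1.7-fold higher number from compound 1 to compound 4 (0.22 log units; within the scatter) expected to be modest and possibly within the scatter. The estimated value for compound 4 in this assay is 60000 nM, with a likely range from 15000 nM to 150000 nM.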

Compound 4, half-maximal inhibitory concentration: 88900 nM
Estimate against measurement, compound 4: 1.5-fold (0.17 log units) below; the measured number falls inside the stated range.
By their numbers in this assay, from the lowest: compound 2; then compound 1; then compound 4. At a limit, above all of these: compound 3.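

In this assay, putting the group of 8 heavy atoms in place of the fluorine-bearing group of 9 heavy atoms, on a saturated chain carbon, two bonds along the chain from a saturated ring carbon, gives a 2.5-fold higher number from compound 1 to compound 4 (0.39 log units; beyond the scatter). Within the data shown here, this is the first step that can be read at this place, and it shows that changing this group alone, with the rest of the core unchanged, moves the number toward weaker inhibition by more than the scatter. Nothing measured here gives a reason for the size or direction of this step.

The compounds shown leave open whether the same step would appear on a different chain, as this single pair is the only evidence at this place. They also leave open how the number would respond to a longer chain, or to a chlorine atom or a methyl group in place of the fluorine.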